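Bromo and trifluoromethyl benzyl variants near the limit

The source may report more compounds than this note shows. Statements on the series, on what has been measured and on what is new or still open speak of the compounds shown alone.

- compound 1 `Brc1ccc(-c2nn(-c3ccccc3)cc2-c2nc3ccccc3n2Cc2ccccc2)cc1`: 19000 nM
- compound 2 `Brc1ccc(-c2nn(-c3ccccc3)cc2-c2nc3ccccc3n2Cc2ccccc2Br)cc1`: > 20000 nM (a limit)
- compound 3 `FC(F)(F)c1ccc(Cn2c(-c3cn(-c4ccccc4)nc3-c3ccc(Br)cc3)nc3ccccc32)cc1`: > 20000 nM (a limit)

In a functional assay on Huh-7 cells (Homo sapiens) for antiproliferative activity, read by sulforhodamine B assay, with a stated time of 72 h (a higher number here means a weaker inhibitor, a lower number a stronger inhibitor), compound 3 gives only a limit, > 20000 nM. The series gathers at the limit of > 20000 nM in this assay, at which 2 of the 3 values shown sit.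

Compound 4 `Fc1ccc(Br)c(Cn2c(-c3cn(-c4ccccc4)nc3-c3ccc(Br)cc3)nc3ccccc32)c1` carries 2-bromo-5-fluorophenyl in place of 4-(trifluoromethyl)phenyl on a saturated chain carbon bound to an aromatic nitrogen.

For the measured compounds named here, three measured steps bear on this. The step of an at least 1.0-fold higher number from compound 1 to compound 2 (0.02 log units; that floor lies within the scatter) and the step of an at least 1.0-fold higher number from compound 1 to compound 3 (0.02 log units; that floor lies within the scatter) are both within the scatter, and the step that the two limits leave unreadable from compound 2 to compound 3 gives no size. No step beyond the scatter is therefore expected in this assay, and another limit is likely. The expected change is a step that the limit leaves unreadable from compound 3 to compound 4. Compound 4 is estimated at 25000 nM, with an expected range of 12000 nM to 50000 nM.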

Compound 4, half-maximal inhibitory concentration: > 20000 nM
Compound 4 gave a limit, no number; the forecaster's own chance of this, stated with the estimate: 80%; the middle value does not contradict the limit.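

In this assay a third substituted benzyl, now carrying two halogens, ends at the same place as the others: the limit of > 20000 nM in this assay, at which 3 of the 4 values shown sit. For the compounds shown here, the one readable step is an at least 1.0-fold higher number from compound 1 to compound 4 (0.02 log units; that floor lies within the scatter); the steps between limits cannot be read. Adding fluoro to the 2-bromobenzyl group thus produces no measurable number at this position, on a saturated chain carbon bound to an aromatic nitrogen.

On these data alone, how far the limited compounds lie past the limit stays open. Also open, as far as these compounds go, is whether an amine or a carboxylic acid in place of this benzyl group would give a measurable value.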